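Reversing the acylhydrazone linker on a shared ether core

This account rests on a few compounds, and the source may have more. Where it says the series, first, only, none or still open, it means among the compounds named here.

Compound 1 `COc1cc2c(Oc3ccc(NC(=O)N/N=C/c4ccc(C(F)(F)F)cc4)cc3F)ccnc2cc1OCCCN1CCCCC1` gives 630 nM in a functional assay on MKN-45 cells (Homo sapiens) for cytotoxicity, read by MTT assay, with a stated time of 72 h; on this read-out higher numbers stand for weaker inhibition and lower numbers for stronger inhibition. Compound 2 `COc1cc2c(Oc3ccc(NC(=O)N/N=C/c4ccncc4)cc3F)ccnc2cc1OCCCN1CCCCC1` gives 980 nM in this assay, the highest of the two numbers shown, though its nearest neighbour, compound 1, sits within the scatter of it. Compound 3 `COc1cc2c(Oc3ccc(/C=N/NC(=O)Nc4ccccc4)cc3F)ccnc2cc1OCCCN1CCCCC1` carries a group of 12 heavy atoms (8 carbon, 3 nitrogen, 1 oxygen; one six-membered aromatic ring of carbon only) in place of a group of 12 heavy atoms (7 carbon, 4 nitrogen, 1 oxygen; one six-membered aromatic ring with 1 hetero atom), on an aromatic carbon, meta to a fluoro group and para to a large group. Among the measured compounds shown here, the one measured step that bears on this change, a 1.6-fold higher number from compound 1 to compound 2 (0.19 log units; within the scatter), stayed within the scatter, so no step beyond the scatter is expected here: a 1.1-fold lower number from compound 2 to compound 3 (0.04 log units; within the scatter). For compound 3 the estimate in this assay is 900 nM, ranging from 250 nM to 3500 nM.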

Compound 3, half-maximal inhibitory concentration: 180 nM
Beside the measured number, compound 3's estimate is 5.0-fold (0.70 log units) above it; measured number outside the range, below it.
By their numbers in this assay, from the lowest: compound 3; then compounds 1 and 2 (each within the scatter of the next).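

In this assay, replacing the whole group on this aromatic carbon moves the number beyond the scatter (a 5.4-fold lower number from compound 2 to compound 3 (0.74 log units; beyond the scatter)), whereas the earlier exchange of the end ring alone stayed within it (a 1.6-fold higher number from compound 1 to compound 2 (0.19 log units; within the scatter)). The step from compound 2 to compound 3 reverses the linker and also exchanges a ring with a hetero atom for one of carbon only, so it cannot be divided between these two changes. Nothing measured here gives a reason for the step.

Going by these compounds, it remains open whether the reversed linker alone accounts for the step, or whether the ring exchange contributes. On these data alone, how an amine or a carboxylic acid on the end ring would read on this reversed linker is also open.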